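Swapping the Pyridyl for an Acetyl Group

This account rests on a few compounds, and the source may have more. Where it says the series, first, only, none or still open, it means among the compounds named here.

The study measures inhibition in an assay (Rattus norvegicus) for inhibition of Fatty-acid amide hydrolase 1 (Homo sapiens); a lower number here means a stronger inhibitor, a higher number a weaker inhibitor. Three compounds share one core. Compound 1 `Nc1ccc(-c2cnc(C(=O)CCCCCCc3ccccc3)o2)cc1` gives 90 nM in this assay, and compound 2 `O=C(O)c1ccc(-c2cnc(C(=O)CCCCCCc3ccccc3)o2)cc1` gives 60 nM; the step of a 1.5-fold lower number from compound 1 to compound 2 (0.18 log units; within the scatter) is small. Compound 3 `Cc1ccnc(-c2cnc(C(=O)CCCCCCc3ccccc3)o2)c1` gives 0.6 nM, the lowest of the three numbers and the strongest inhibitor, since both a 150-fold lower number from compound 1 to compound 3 (2.18 log units; beyond the scatter) and a 100-fold lower number from compound 2 to compound 3 (2.00 log units; beyond the scatter) are large.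

Compound 4 `CC(=O)c1cnc(C(=O)CCCCCCc2ccccc2)o1` has not yet been measured. Its change from compound 3 is acetyl in place of 4-methylpyridin-2-yl on an aromatic carbon. Going by the values given here, no measured step covers this change directly. What the data show is that the 4-methylpyridin-2-yl group was associated with the two large steps from compound 1 and compound 2 to compound 3, so removing it in favour of an acetyl group is expected to cost much of that gain. Compound 4 is therefore expected to give a markedly higher number, estimated at 300 nM with a range of 60 nM to 1500 nM, a step of a 500-fold higher number from compound 3 to compound 4 (2.70 log units; beyond the scatter).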

Compound 4, inhibition constant: 2 nM
For compound 4 the middle estimate is 150-fold (2.18 log units) above the measured one; the whole stated range lies above it.
By their numbers in this assay, from the lowest: compound 3; then compound 4; then compounds 2 and 1 (each within the scatter of the next).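

In this assay the aromatic carbon next to the ring oxygen turns out not to need a ring for a low number: the acetyl group, with 3 heavy atoms and no ring, gives only a 3.3-fold higher number from compound 3 to compound 4 (0.52 log units; beyond the scatter) and stays modest against the 4-methylpyridin-2-yl group. The same acetyl group also lies far from the two substituted phenyl groups, with a 30-fold lower number from compound 2 to compound 4 (1.48 log units; beyond the scatter) and a 45-fold lower number from compound 1 to compound 4 (1.65 log units; beyond the scatter), so among these compounds a low number is not tied to the 4-methylpyridin-2-yl group alone. No supporting data bear on why these numbers fall as they do.

The compounds shown leave open how a methyl ester, an amide or a bare hydrogen on this carbon would compare with the acetyl group. They also leave open how an unsubstituted phenyl ring would stand against the 4-aminophenyl and 4-carboxyphenyl groups.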